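Removing the Carbamoyl Group from a Weak Inhibitor

The source may report more compounds than this note shows. Statements on the series, on what has been measured and on what is new or still open speak of the compounds shown alone.

Compound 1, `CCOC(=O)C1=Cc2ccc(OC)cc2OC1c1cc(OC)c(OC)c(OC)c1`: in a functional assay for inhibition of nuclear factor NF-kappa-B complex (Homo sapiens) (a higher number here means a weaker inhibitor, a lower number a stronger inhibitor), compound 1 gives 25000 nM.
Compound 2, `COc1ccc2c(c1)OC(c1cc(OC)c(OC)c(OC)c1)C(C(N)=O)=C2`: in this assay compound 2 reaches only a limit of the assay, > 50000 nM.
Compound 3, `COC(=O)C1=Cc2ccc(OC)cc2OC1c1cc(OC)c(OC)c(OC)c1`: in this assay compound 3 gives 13800 nM.

Going by the values given here, compound 2 is the one compound that sits at the limit (the limit of > 50000 nM in this assay, at which 1 of the 3 values shown sits), so its number is not known, only that it is weaker than the two esters. Compared with compound 1 the step was an at least 2.0-fold higher number from compound 1 to compound 2 (0.30 log units; that floor lies within the scatter), and compared with compound 3 it was an at least 3.6-fold lower number from compound 2 to compound 3 (0.55 log units; beyond the scatter).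

Compound 4, `COc1ccc2c(c1)OC(c1cc(OC)c(OC)c(OC)c1)C=C2`, takes the change (hydrogen in place of carbamoyl on a double-bonded ring carbon). Among the compounds with values here, both measured steps swap the group on the carbonyl carbon; neither removes the whole carbonyl-bearing group from the ring, so no measured step matches this change directly. The esters in compound 1 and compound 3 show that the carbamoyl is not needed for the weak inhibition seen, but they give no sign that a bare ring carbon helps. The step of an at least 1.6-fold lower number from compound 2 to compound 4 (0.22 log units; that floor lies within the scatter) is therefore expected to be small and uncertain. Compound 4 is estimated at 30000 nM, within 10000 nM to 100000 nM.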

Compound 4, half-maximal inhibitory concentration: 17700 nM
The estimate for compound 4 lay 1.7-fold (0.23 log units) above the measured number; the range from low to high includes it.
By their numbers in this assay, from the lowest: compounds 3, 4 and 1 (each within the scatter of the next). At a limit, above all of these: compound 2.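

In this assay, hydrogen in place of carbamoyl on this double-bonded ring carbon gives an at least 2.8-fold lower number from compound 2 to compound 4 (0.45 log units; beyond the scatter), so the weak inhibition does not depend on a carbonyl-bearing group at this position. Compound 2 is only a limit of the assay, so the size of that step is a floor and not a measured gap: the limit of > 50000 nM in this assay, at which 1 of the 4 values shown sits.

The two esters do not separate from the bare ring carbon: hydrogen in place of methoxycarbonyl gives a 1.3-fold higher number from compound 3 to compound 4 (0.11 log units; within the scatter), and hydrogen in place of ethoxycarbonyl gives a 1.4-fold lower number from compound 1 to compound 4 (0.15 log units; within the scatter).

Still open, from the compounds shown here alone, is whether another group on this carbon, such as a carboxylic acid, an amine or a longer alkyl chain, would move the number beyond the scatter from compound 4. The compounds shown also say nothing about changes elsewhere on the shared core, including the ring atom that bears a large group.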